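The source may hold more compounds than are shown below. What is called first, only, known or untested is meant among the compounds shown, and "the series" means these compounds.

Measured compounds:
- compound 2 `NC(N)=NC(=O)c1nc(Cl)c(NC2CC2)nc1N` — inhibition read-out 78%
- compound 1 `NC(N)=NC(=O)c1nc(Cl)c(NCC2CCc3ccccc3C2)nc1N` — inhibition read-out "not determined" (no result reported)
- compound 3 `NC(N)=NC(=O)c1nc(Cl)c(Nc2ccc(C(F)(F)F)cc2)nc1N` — inhibition read-out "not determined" (no result reported)

For the measured compounds named here, compound 2 is the only member of the series with a number in an assay for inhibition of acid-sensing ion channel 3 (Homo sapiens), read by patch clamp, tested at 20 uM; on this read-out higher numbers stand for more inhibition at the one concentration tested (going by the name of the read-out) and lower numbers for less inhibition; compound 1 and compound 3 stand without a result, so there is no step between measured compounds to lean on, and no pattern can be drawn from what has been recorded.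

Compound 4 `NC(N)=NC(=O)c1nc(Cl)c(Oc2ccccc2)nc1N` is not yet measured. The change from compound 2 to compound 4 is phenoxy in place of cyclopropylamino on an aromatic carbon. The hydrogen-bond donor of the cyclopropylamino group is lost and a six-membered aromatic ring of carbon takes the place of the three-membered ring.

With no measured step of this kind in hand, the expectation for this assay rests on compound 2 alone. A moderate drop is expected, a step beyond the usual scatter but not a loss of most of the inhibition. On that basis the expected step from compound 2 to compound 4 is a number 23 percentage points lower from compound 2 to compound 4 (beyond the scatter). Compound 4 is expected to give about 55%, with a range from 25% to 85%.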

Compound 4, a percentage reported as inhibition, at one concentration (the size of the read-out at that concentration, not a potency): 90%
Compound 4: the middle estimate sits 35 percentage points below what was measured; the whole stated range lies below it.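

In this assay, phenoxy in place of cyclopropylamino on an aromatic carbon gives a number 12 percentage points higher from compound 2 to compound 4 (beyond the scatter). The position next to the ring nitrogen and ortho to a chloro group therefore keeps its inhibition without the hydrogen-bond donor of the cyclopropylamino group and with a six-membered aromatic ring in place of the three-membered ring, at least in this one pair. Nothing measured here explains the rise.

The compounds shown leave open whether the rise goes with the oxygen link or with the aromatic ring; a pair with phenylamino or cyclopropyloxy at this position would separate the two. Going by these compounds, both values come from one concentration, so how far the step carries over to potency also remains open.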